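A Methoxy Group on the Phenyl Ether

A few compounds are considered here, and "the series" means these few. Any claim that something is new, unique, unknown or untested is made for them only; others in the source may bear on it.

Measured so far:
compound 1, `C/C(=C\COc1c(Cl)cccc1Cl)CC/C=C(\C)C1=CC(=O)C(C)(C)O1`, 35.3 ug/mL
compound 2, `C/C(=C\COc1ccccc1)CC/C=C(\C)C1=CC(=O)C(C)(C)O1`, 44.2 ug/mL

Of the compounds shown here, two have been measured in a functional assay on FM3A cells (Mus musculus) for inhibition; a higher number here means a weaker inhibitor, a lower number a stronger inhibitor. Compound 1 `C/C(=C\COc1c(Cl)cccc1Cl)CC/C=C(\C)C1=CC(=O)C(C)(C)O1` gives 35.3 ug/mL in this assay, and compound 2 `C/C(=C\COc1ccccc1)CC/C=C(\C)C1=CC(=O)C(C)(C)O1` gives 44.2 ug/mL. Within the data shown here, compound 2 holds the higher of the two numbers, yet its only neighbour lies within the scatter: a 1.3-fold higher number from compound 1 to compound 2 (0.10 log units; within the scatter). Compound 3 `COc1ccc(OC/C=C(\C)CC/C=C(\C)C2=CC(=O)C(C)(C)O2)cc1` has not yet been measured. It differs from compound 2 in one place: methoxy in place of hydrogen on an aromatic carbon. Among the measured compounds shown here, the single measured step also changes the substitution of this same aromatic ring, trading 2,6-dichlorophenyl for phenyl, and it stays within the scatter. For the measured compounds named here, no measured step puts a methoxy onto the ring, so the expectation rests on that one small step alone. The step to compound 3 is therefore expected to be small, a 1.1-fold lower number from compound 2 to compound 3 (0.04 log units; within the scatter), not beyond the scatter. Compound 3 is estimated at 40 ug/mL, within a range from 20 ug/mL to 80 ug/mL.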

Compound 3, half-maximal inhibitory concentration: 43.8 ug/mL
Estimate against measurement, compound 3: 1.1-fold (0.04 log units) below; low and high end bracket the measured number.
By their numbers in this assay, from the lowest: compounds 1, 3 and 2 (each within the scatter of the next).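

Methoxy on an aromatic carbon, para to a large group, is the first group added to the plain phenyl ring, and in this assay it gives a 1.0-fold lower number from compound 2 to compound 3 (0.00 log units; within the scatter). Against the 2,6-dichlorophenyl ring, the 4-methoxyphenyl ring gives a 1.2-fold higher number from compound 1 to compound 3 (0.09 log units; within the scatter), so compounds 1, 2 and 3, with three different substitutions on this ring, cannot be told apart in this assay. No evidence is at hand to explain this result.

All three compounds keep the same chain and core, so they leave open whether an amine or a carboxylic acid on the same aromatic carbon would also stay within the scatter of compound 2. On these data alone, whether a longer chain between the ring oxygen and the core would do so also remains open.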